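Chloro Removal on the Shared Core: Estimate for Compound 4

The source may hold more compounds than are shown below. What is called first, only, known or untested is meant among the compounds shown, and "the series" means these compounds.

Of the compounds shown here, three have been measured so far, all built on the same shared core and differing only in their chloro groups. Compound 1 `ClCc1ccc(Cn2cnc3c(Cl)ncnc32)cc1` is the simplest of them; in a functional assay on HOP-62 cells (Homo sapiens) for cytotoxicity, read by sulforhodamine B assay, with a stated time of 48 h (a higher number here means that more compound is tolerated, a lower number that less compound is tolerated), compound 1 gives 32400 nM. Compound 3 `ClCc1ccc(Cn2cnc3c(Cl)nc(Cl)nc32)cc1` is its close relative; in this assay compound 3 gives 19500 nM. The change from compound 3 to compound 1 is hydrogen in place of chloro on an aromatic carbon, and it produced a 1.7-fold higher number from compound 3 to compound 1 (0.22 log units; within the scatter). Compound 2 `ClCc1ccc(Cn2cnc3nc(Cl)nc(Cl)c32)cc1` has the same atoms as compound 3 joined differently; the difference between the two cores is not broken down here. In this assay compound 2 gives 7940 nM, the lowest of the three numbers, with steps to compound 3 and to compound 1 that both lie beyond the scatter.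

Compound 4 `ClCc1ccc(Cn2cnc3ncnc(Cl)c32)cc1` has not yet been measured. From compound 2 to compound 4 the change is hydrogen in place of chloro on an aromatic carbon, the same change as from compound 3 to compound 1, at a place described in the same words. Because the earlier instance gave a 1.7-fold higher number from compound 3 to compound 1 (0.22 log units; within the scatter), a step of similar size, a 1.7-fold higher number from compound 2 to compound 4 (0.23 log units; within the scatter), is expected from compound 2 to compound 4 in this assay. On this basis compound 4 is estimated at 13500 nM in this assay. The expected range for compound 4 runs from 5500 nM to 33000 nM, which allows for the scatter of this kind of measurement on a single precedent.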

Compound 4, concentration lethal to 50% of the cells: 5620 nM
Beside the measured number, compound 4's estimate is 2.4-fold (0.38 log units) above it; the range from low to high includes it.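

In this assay, hydrogen in place of chloro on an aromatic carbon, here between two ring nitrogen atoms, gives a 1.4-fold lower number from compound 2 to compound 4 (0.15 log units; within the scatter), and set beside the earlier instance on the other core the two steps do not separate: the same change on two cores in this assay, a 1.7-fold higher number (0.22 log units; within the scatter) from compound 3 to compound 1 and a 1.4-fold lower number (0.15 log units; within the scatter) from compound 2 to compound 4, 2.3-fold (0.37 log units) apart, within the scatter of two such steps. For the compounds shown here, on these two cores, then, the change gives no step that can be told from the scatter, and the opposite directions of the two steps are no evidence that the cores respond differently. Going by these compounds alone, this does not show that the change is without consequence in general or that a step of a fixed size carries over, since it rests on only two pairs of compounds, and steps this small cannot establish a size or direction to transfer to a further core.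

The compounds shown vary only chloro and hydrogen on the aromatic ring carbons and the way the core is joined, so whether an amine or a methoxy group at the same aromatic carbon would give a step beyond the scatter in this assay remains open. Also open, as far as these compounds go, is how the numbers would respond to a longer chain in place of the chloromethyl group, which stays the same across all four compounds.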